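Acetyl becomes ethoxycarbonyl on compound 3

This account rests on a few compounds, and the source may have more. Where it says the series, first, only, none or still open, it means among the compounds named here.

Among the measured compounds shown here, three related compounds have numbers so far in a functional assay on HepG2 cells (Homo sapiens) for antiproliferative activity, read by MTT assay, with a stated time of 48 h (a higher number here means a weaker inhibitor, a lower number a stronger inhibitor), and they spread widely. Compound 2 `COc1ccc(/C=C(\C#N)C(=O)N/N=C(\C)c2cc3cccc(OC)c3oc2=O)cc1` reads 770 nM while compound 1 `COc1cc(/C=C/C(=O)c2cc3cccc(OC)c3oc2=O)cc(OC)c1OC` reads 2020 nM on the same scale. Compound 3 `COc1cccc2cc(-c3ccc(C(C)=O)c(C)n3)c(=O)oc12` gives the highest of the three numbers at 9100 nM which makes it the weakest inhibitor of the set, and its gaps to both of the others lie beyond the usual scatter of repeated measurements.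

Compound 4 `CCOC(=O)c1ccc(-c2cc3cccc(OC)c3oc2=O)nc1C` is compound 3 with one small edit: ethoxy in place of methyl on a carbonyl carbon so that acetyl becomes ethoxycarbonyl. Everything else stays the same. For the measured compounds named here, no two measured compounds differ in just one place, so the data hold no direct precedent for this swap. Compound 1 and compound 2 differ from compound 3 in too much to serve as a guide, which leaves compound 3 at 9100 nM as the only sensible starting point.

The expectation in this assay is therefore no step beyond the scatter, with at most a slight drift towards a lower number. The estimated step is a 1.3-fold lower number from compound 3 to compound 4 (0.11 log units; within the scatter) and it remains a modest one. For compound 4 the expected value is 7000 nM with an estimated range of 2500 nM to 20000 nM here.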

Compound 4, half-maximal inhibitory concentration: 4920 nM
Beside the measured number, compound 4's estimate is 1.4-fold (0.15 log units) above it, and the stated range covers the measured number.
By their numbers in this assay, from the lowest: compound 2; then compound 1; then compounds 4 and 3 (each within the scatter of the next).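

In this assay the change from acetyl to ethoxycarbonyl gives a 1.8-fold lower number from compound 3 to compound 4 (0.27 log units; within the scatter) and this step lies within the scatter, so the two compounds read as equal on this scale. Among the compounds shown here, this is the first pair that differs in one place, and so the first direct reading at this spot: on a carbonyl carbon whose other neighbours are aromatic carbon, methyl can give way to the bigger ethoxy, with its extra oxygen, without a shift the assay can resolve. No separate measurement bears on why the number holds steady here.

A single swap at a single position does not show how far this holds. A carboxylic acid, an amide or a longer chain such as butoxy on the same carbonyl carbon would show whether the position stays this indifferent, or whether a group of another kind moves the number beyond the scatter.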